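Replacing the nitrophenyl of compound 1 with trifluoromethylphenyl

The source may hold more compounds than are shown below. What is called first, only, known or untested is meant among the compounds shown, and "the series" means these compounds.

Three compounds share one core and differ only in the aromatic group attached to it. Compound 1 `COc1cc(C(=O)c2sc(-c3cccc([N+](=O)[O-])c3)cc2N)cc(OC)c1OC` gives 11 nM in a functional assay on L1210 cells (Mus musculus) for antiproliferative activity (a lower number here means a stronger inhibitor, a higher number a weaker inhibitor), the lowest of the three numbers, though both neighbours sit within the usual scatter. Compound 2 `COc1cc(C(=O)c2sc(-c3ccc(F)cc3)cc2N)cc(OC)c1OC` gives 20 nM and compound 3 `COc1cccc(-c2cc(N)c(C(=O)c3cc(OC)c(OC)c(OC)c3)s2)c1` gives 22 nM; the steps of a 1.8-fold higher number from compound 1 to compound 2 (0.26 log units; within the scatter) and a 2.0-fold higher number from compound 1 to compound 3 (0.30 log units; within the scatter) are both small. Compound 4 `COc1cc(C(=O)c2sc(-c3ccc(C(F)(F)F)cc3)cc2N)cc(OC)c1OC` is not yet measured and differs from compound 1 in one place: 4-(trifluoromethyl)phenyl in place of 3-nitrophenyl on an aromatic carbon. Among the measured compounds shown here, the closest precedent is the step of a 1.8-fold higher number from compound 1 to compound 2 (0.26 log units; within the scatter), which also exchanged 3-nitrophenyl for a fluorine-bearing phenyl and stayed within the scatter. Compound 4 is therefore expected to show a 1.6-fold higher number from compound 1 to compound 4 (0.21 log units; within the scatter), nothing beyond the scatter. Compound 4 is estimated at 18 nM, ranging from 7 nM to 50 nM.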

Compound 4, half-maximal inhibitory concentration: 370 nM
Compound 4: the middle estimate sits 21-fold (1.31 log units) below what was measured; the whole stated range lies below it.
By their numbers in this assay, from the lowest: compounds 1, 2 and 3 (each within the scatter of the next); then compound 4.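

In this assay, 3-nitrophenyl, 4-fluorophenyl and 3-methoxyphenyl all gave numbers within the scatter of one another, but 4-(trifluoromethyl)phenyl gives a 34-fold higher number from compound 1 to compound 4 (1.53 log units; beyond the scatter), so this position does not accept every substituted phenyl alike. The change can be as small as trifluoromethyl in place of fluoro, with a 19-fold higher number from compound 2 to compound 4 (1.27 log units; beyond the scatter), and the comparison with the methoxy compound gives a 17-fold higher number from compound 3 to compound 4 (1.23 log units; beyond the scatter). No measurement shown here explains this loss. Still open, going by these compounds, is whether a methyl group or a chlorine in place of the trifluoromethyl would keep the number of compound 2 or follow compound 4.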